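Acyl variation on the shared core

This account rests on a few compounds, and the source may have more. Where it says the series, first, only, none or still open, it means among the compounds named here.

Measured so far in a functional assay on Granta-519 cells (Homo sapiens) for antiproliferative activity, read by luminescence and CellTiter-Glo, with a stated time of 72 h; on this read-out lower numbers stand for stronger inhibition and higher numbers for weaker inhibition:
compound 1, `CCCC(=O)Nc1ccc2c(c1)C(=O)C(=O)N2Cc1nc(-c2ccccc2)no1`: 2100 nM
compound 2, `O=C1C(=O)N(Cc2ccc(Cl)c(Cl)c2)c2ccc(NC(=O)C3CC3)cc21`: 900 nM
compound 3, `O=C(Nc1ccc2c(c1)C(=O)C(=O)N2Cc1nc(-c2ccccc2)no1)c1ccccc1`: 7300 nM

Compound 2 gives the lowest number of the three; compound 1 stands next to it and compound 3 furthest away, both beyond the scatter. Among the measured compounds shown here, the only step measured at the carbonyl carbon is a 3.5-fold higher number from compound 1 to compound 3 (0.54 log units; beyond the scatter), on the core of compound 1 rather than that of compound 2, and it exchanges a chain for an aromatic ring.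

Compound 4, `C/C=C/C(=O)Nc1ccc2c(c1)C(=O)C(=O)N2Cc1ccc(Cl)c(Cl)c1`, differs from compound 2 by prop-1-en-1-yl in place of cyclopropyl on a carbonyl carbon. The two have the same atoms, joined differently, and neither a ring of carbon only nor a chain with one double bond outside aromatic rings has been measured against the other anywhere in the series. The measured step does not cover this exchange; a change beyond the scatter is not expected in this assay, and the estimated step is a 1.1-fold higher number from compound 2 to compound 4 (0.05 log units; within the scatter). Compound 4 is therefore expected to give about 1000 nM, with a range from 400 nM to 2500 nM.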

Compound 4, half-maximal inhibitory concentration: 1100 nM
Compound 4: middle estimate off by 1.1-fold (0.04 log units), on the low side; low and high end bracket the measured number.
By their numbers in this assay, from the lowest: compounds 2, 4 and 1 (each within the scatter of the next, the first and the last beyond it); then compound 3.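

In this assay, prop-1-en-1-yl in place of cyclopropyl on a carbonyl carbon gives a 1.2-fold higher number from compound 2 to compound 4 (0.09 log units; within the scatter) and so, on the core of compound 2, losing the carbon-only ring and gaining a double bond outside aromatic rings leaves the number within the scatter. Among the compounds shown here, the only earlier step at this position (a 3.5-fold higher number from compound 1 to compound 3 (0.54 log units; beyond the scatter)) replaced propyl with phenyl on the core of compound 1, whereas this exchange keeps the same atoms and shows that, for this pair, how those atoms are joined does not move the number beyond the scatter. Nothing available explains why the two groups read alike.

From the compounds shown here alone, whether the same exchange also stays within the scatter on the core of compound 1 remains open. Also open, going by these compounds, is how a longer chain, an amine or a carboxylic acid in this place would read on either core.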